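This account rests on a few compounds, and the source may have more. Where it says the series, first, only, none or still open, it means among the compounds named here.

Measured so far in an assay on isolated protein for inhibition of Amine oxidase [flavin-containing] B (Homo sapiens); a lower number here means a stronger inhibitor, a higher number a weaker inhibitor:
compound 1 `C#CCNC1CCc2c(SCCc3cccc(C)c3)cccc21` — 0.35 nM
compound 2 `C#CCNC1CCc2c(SCc3ccc(C(F)(F)F)cc3)cccc21` — 9680 nM
compound 3 `C#CCNC1CCc2c(SCc3ccc(F)cc3F)cccc21` — 2430 nM

Compound 1 holds the lowest number of the three. Compound 3 stands far above it and compound 2 further still; both gaps lie well beyond the scatter. Within the data shown here, no two of the measured compounds differ in one place only, so no single measured step exists. Compound 1 differs from compound 2 and from compound 3 in more than one place, and these numbers cannot be split among those places.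

Compound 4 `C#CCNC1CCc2c(SCCc3ccc(C)cc3)cccc21` is the next compound. 4-methylphenyl in place of 3-methylphenyl on a saturated chain carbon, two bonds along the chain from a sulfur The two compounds hold the same atoms, joined differently. Among the measured compounds shown here, no measured step speaks to a change of this kind, so the expectation rests on compound 1 alone. The step of a 2.3-fold higher number from compound 1 to compound 4 (0.36 log units; beyond the scatter) is expected to be small, within or near the scatter, with a slight rise as the more likely direction. For compound 4 the estimate is 0.8 nM, between 0.2 nM and 8 nM.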

Compound 4, half-maximal inhibitory concentration: 25800 nM
The estimate for compound 4 lay 32000-fold (4.51 log units) below the measured number, and the stated range ends below it.
By their numbers in this assay, from the lowest: compound 1; then compound 3; then compound 2; then compound 4.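

In this assay, 4-methylphenyl in place of 3-methylphenyl on a saturated chain carbon, two bonds along the chain from a sulfur, gives a 74000-fold higher number from compound 1 to compound 4 (4.87 log units; beyond the scatter). Among these compounds, the two compounds hold the same atoms, so the way these atoms are joined at this one place carries the whole step, a single-place reading that the earlier compounds, each differing from compound 1 in more than one place, could not give. Nothing at hand gives a reason for a step of this size.

On these data alone, it stays open whether the low number of compound 1 needs the methyl group at all, or whether a plain phenyl, a chlorine or a methoxy group would hold it. As far as these compounds go, how a longer chain would act with either methylphenyl group also remains unknown.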